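The source may report more compounds than this note shows. Statements on the series, on what has been measured and on what is new or still open speak of the compounds shown alone.

Measured so far in a functional assay on isolated protein for antagonist activity at C-C chemokine receptor type 9 (Homo sapiens), read by calcium flux, with a stated time of 10 min; on this read-out lower numbers stand for stronger inhibition and higher numbers for weaker inhibition:

Compound 1 `COc1cccnc1-c1cc(Cl)ccc1NS(=O)(=O)c1ccc(C(C)(C)C)cc1`: 958 nM
Compound 2 `CC(C)(C)c1ccc(S(=O)(=O)Nc2ccc(Cl)cc2-c2ncccc2N)cc1`: 95 nM
Compound 3 `CC(C)(C)c1ccc(S(=O)(=O)Nc2ccc(Cl)cc2-c2nccc(C(N)=O)c2O)cc1`: 52 nM

Compound 3 stands at the low end of the three numbers in this assay. Its distance from compound 1 is clear: an 18-fold lower number from compound 1 to compound 3 (1.27 log units; beyond the scatter). Its distance from compound 2, however, is only a 1.8-fold lower number from compound 2 to compound 3 (0.26 log units; within the scatter), so compound 2 and compound 3 cannot be separated on these data. The earlier step of a 10-fold lower number from compound 1 to compound 2 (1.00 log units; beyond the scatter) shows that exchanging the substituent on the attached aromatic ring can move the number considerably.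

Compound 4 `CNc1ncc(O)c(-c2cc(Cl)ccc2NS(=O)(=O)c2ccc(C(C)(C)C)cc2)n1` carries the change (a group of 9 heavy atoms (5 carbon, 3 nitrogen, 1 oxygen; one six-membered aromatic ring with 2 hetero atoms) in place of a group of 10 heavy atoms (6 carbon, 2 nitrogen, 2 oxygen; one six-membered aromatic ring with 1 hetero atom), on an aromatic carbon). The ring that leaves holds 2 hydrogen-bond donors and 3 acceptors with 1 double bond outside aromatic rings; the ring that enters holds 2 donors and 4 acceptors and has 2 hetero atoms in the six-membered aromatic ring. Among the measured compounds shown here, the steps that bear on this are the exchanges of the same group in compound 1, compound 2 and compound 3, where the large shift came from compound 1 and the exchange between compound 2 and compound 3 stayed within the scatter. A ring of comparable size and donor count is expected to behave more like the latter pair.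

Compound 4 is therefore estimated at 80 nM in this assay, with a range from 25 nM to 250 nM. For compound 4 this corresponds to an expected step of a 1.5-fold higher number from compound 3 to compound 4 (0.19 log units; within the scatter), which is expected to remain within the scatter.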

Compound 4, half-maximal inhibitory concentration: 27 nM
Estimate against measurement, compound 4: 3.0-fold (0.47 log units) above, within the range that was stated.
By their numbers in this assay, from the lowest: compounds 4, 3 and 2 (each within the scatter of the next, the first and the last beyond it); then compound 1.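

In this assay, the entering ring, a six-membered aromatic ring with 2 hetero atoms, takes the place of the ring in compound 3 with a 1.9-fold lower number from compound 3 to compound 4 (0.28 log units; within the scatter), so at this position, on an aromatic carbon and ortho to a large group, the two rings cannot be told apart. Among the compounds shown here, what compound 3 did not show is a separation from compound 2: a 3.5-fold lower number from compound 2 to compound 4 (0.55 log units; beyond the scatter), so this ring, unlike the one in compound 3, stands clear of compound 2, while a 35-fold lower number from compound 1 to compound 4 (1.55 log units; beyond the scatter) confirms a wide distance from the compound carrying the methoxy group. No measurement shown here accounts for any of these steps.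

The entering ring differs from the others in several features at once, so the compounds shown do not say whether its extra ring nitrogen, its hydroxyl group or its methylamino group carries the difference from compound 2. They also leave open how the number would respond if a plain amine, an ethylamino chain or a carboxylic acid stood on this ring in place of the methylamino group.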